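The source may hold more compounds than are shown below. What is called first, only, known or untested is meant among the compounds shown, and "the series" means these compounds.

Compound 1 `COc1cc(NC(C)CCCNC(=O)NNC(=O)Nc2cc(C(F)(F)F)cc(C(F)(F)F)c2)c2ncccc2c1` and compound 2 `COc1cc(NC(C)CCCNC(=O)Nc2ccc(F)cc2)c2ncccc2c1` share one core and differ in a single region. In a functional assay on L1210 cells (Mus musculus) for inhibition, read by MTT assay, with a stated time of 72 h (a higher number here means a weaker inhibitor, a lower number a stronger inhibitor), compound 1 gives 18000 nM. In this assay compound 2 gives 18000 nM, level with compound 1 at the digits recorded and within the usual scatter. Compound 3 `COc1cc(NC(C)CCCNC(=O)Nc2ccc(C(F)(F)F)cc2)c2ncccc2c1` has not yet been measured; it differs from compound 2 by trifluoromethyl in place of fluoro on an aromatic carbon. For the measured compounds named here, no measured pair carries this change, so any expectation rests on compound 2 alone. Compound 3 is expected to show a step of a 1.5-fold lower number from compound 2 to compound 3 (0.18 log units; within the scatter), a modest move toward stronger inhibition that may not exceed the scatter. Compound 3 is estimated at 12000 nM, between 4000 nM and 40000 nM.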

Compound 3, half-maximal inhibitory concentration: 7400 nM
Beside the measured number, compound 3's estimate is 1.6-fold (0.21 log units) above it; the range from low to high includes it.
By their numbers in this assay, from the lowest: compound 3; then compounds 1 and 2 (each within the scatter of the next).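

In this assay, for the compounds shown here, the change from 4-fluorophenyl to 4-(trifluoromethyl)phenyl gives a 2.4-fold lower number from compound 2 to compound 3 (0.39 log units; beyond the scatter) and so supplies the first step that can be read at this position. It shows that the number responds to the group on this aromatic carbon, though the step is modest and lies only just beyond the scatter. Nothing at hand explains the step.

As far as these compounds go, whether a chlorine atom, a methyl or a nitrile in this place would follow compound 3 or stay with compound 2 remains open. So does the effect of an amine or a carboxylic acid here.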